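Swapping Diformylphenyl for Difluorophenyl on a Shared Core

The compounds below may be only part of what the source reports. "The series", "measured", "known", "first", "only" and "open" are said of these compounds alone.

Among the compounds with values here, compound 1 `Cc1ccc2c(c1)/C(=c1/sc(=Cc3ccc(C=O)c(C=O)c3)c(=O)n1CCN(C)C)C(=O)N2` is one of two compounds measured in a functional assay on MDA-MB-231 cells (Homo sapiens) for inhibition, read by MTT assay, with a stated time of 72 h (on this read-out lower numbers stand for stronger inhibition and higher numbers for weaker inhibition), where compound 1 gives 8100 nM. This is the highest of the two numbers. Compound 2 `CCN(CC)CCCn1c(=O)c(=Cc2ccc(F)c(F)c2)s/c1=C1\C(=O)Nc2ccc(F)cc21` gives 1220 nM in this assay, a lower number than that of compound 1, and the gap between the two is beyond the scatter of repeated measurements. Within the data shown here, compound 2 differs from compound 1 in more than one place, so no single step links them.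

Compound 3 `Cc1ccc2c(c1)/C(=c1/sc(=Cc3ccc(F)c(F)c3)c(=O)n1CCN(C)C)C(=O)N2` has not been measured. It differs from compound 1 in one place: 3,4-difluorophenyl in place of 3,4-diformylphenyl on a double-bonded chain carbon bound to an aromatic carbon. Among the measured compounds shown here, no measured pair shows this exact change on this core. Since compound 2, which carries a 3,4-difluorophenyl group, gives 1220 nM, the step from compound 1 to compound 3 is expected to be a 3.7-fold lower number from compound 1 to compound 3 (0.57 log units; beyond the scatter), toward a lower number. Compound 3 is therefore estimated to give about 2200 nM in this assay, with a range from 700 nM to 7000 nM.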

Compound 3, half-maximal inhibitory concentration: > 200000 nM
Compound 3: a limit, no number; the forecaster's own chance of this, stated with the estimate: 3%; middle value at least 90-fold (1.95 log units) from the limit.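

In this assay, compound 3 carries a limit and not a number: the limit of > 200000 nM in this assay, at which 1 of the 3 values shown sits. The change to 3,4-difluorophenyl in place of 3,4-diformylphenyl on a double-bonded chain carbon bound to an aromatic carbon gives an at least 24-fold higher number from compound 1 to compound 3 (1.39 log units; beyond the scatter). Within the data shown here, this is the first single-place step, and it shows that on the shared core this one position can move the read-out well beyond the scatter, with the 3,4-diformylphenyl compound on the side of stronger inhibition.

The compounds shown leave open whether a phenyl ring with a single formyl group, a carboxylic acid or a methoxy group at this place would keep a measurable number. They also leave open how the same change would read with the diethylamino propyl chain of compound 2 on the ring nitrogen.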